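The source may hold more compounds than are shown below. What is called first, only, known or untested is meant among the compounds shown, and "the series" means these compounds.

Measured so far:
Compound 1 `COc1ccc(-c2[nH]c3ccccc3c2/C=C(\C#N)S(=O)(=O)c2ccccc2)cc1`, in a functional assay on SF-295 cells (Homo sapiens) for inhibition, read by sulforhodamine B assay, with a stated time of 48 h (on this read-out lower numbers stand for stronger inhibition of growth and higher numbers for weaker inhibition of growth), compound 1 gives 500 nM.
Compound 2 `COc1ccc2[nH]c(-c3ccccc3)c(/C=C(\C#N)S(=O)(=O)c3ccccc3)c2c1`, in this assay compound 2 gives 2800 nM.

Compound 2 has the highest of the two numbers, and its gap to compound 1 lies beyond the usual scatter. Compound 3 `N#C/C(=C\c1c(-c2ccccc2)[nH]c2ccccc12)S(=O)(=O)c1ccccc1` is the next step: hydrogen in place of methoxy on an aromatic carbon. For the measured compounds named here, no measured pair shows this change, so the size of its effect is unknown; a modest move toward a lower number seems plausible. The step from compound 2 to compound 3 is expected to be a 2.2-fold lower number from compound 2 to compound 3 (0.33 log units; beyond the scatter), giving compound 3 an estimated 1300 nM, in the range 400 nM to 4000 nM.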

Compound 3, concentration for 50% growth inhibition: 2400 nM
Compound 3: middle estimate off by 1.8-fold (0.27 log units), on the low side; the measured number falls inside the stated range.
By their numbers in this assay, from the lowest: compound 1; then compounds 3 and 2 (each within the scatter of the next).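

Swapping methoxy for hydrogen on the fused part of the core barely registers: the step is a 1.2-fold lower number from compound 2 to compound 3 (0.07 log units; within the scatter), so in this assay growth inhibition does not depend on methoxy at this place. The same swap at the place methoxy occupies in compound 1 is a different matter, with a 4.8-fold higher number from compound 1 to compound 3 (0.68 log units; beyond the scatter), so the effect of this change depends on where it is made. Nothing measured here explains this contrast. As far as these compounds go, whether a hydroxyl, an amine or a longer chain such as ethoxy would match methoxy at either place remains open.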